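Chloro in place of methyl on an aromatic carbon

A few compounds are considered here, and "the series" means these few. Any claim that something is new, unique, unknown or untested is made for them only; others in the source may bear on it.

In a functional assay on SK-MEL-2 cells (Homo sapiens) for cytotoxicity (on this read-out lower numbers stand for stronger inhibition and higher numbers for weaker inhibition), compound 1 (`O=C1NC(c2ccc(Cl)cc2)CN1S(=O)(=O)c1ccc2c(c1)CCC2`) gives 64300 nM and compound 2 (`Cc1ccc(C2CNC(=O)N2S(=O)(=O)c2ccc3c(c2)CCC3)cc1`) gives 88600 nM, two values within the scatter of each other. Compound 3 (`O=C1NCC(c2ccc(Cl)cc2)N1S(=O)(=O)c1ccc2c(c1)CCC2`) has not yet been measured. It carries chloro in place of methyl on an aromatic carbon of compound 2 (chloro in place of methyl on an aromatic carbon). Among the measured compounds shown here, no measured pair shows this change, so no step beyond the scatter is expected in this assay, in either direction. The expected change is small, a 1.3-fold lower number from compound 2 to compound 3 (0.10 log units; within the scatter) as estimated here. Compound 3 is estimated at 70000 nM, with an expected range of 30000 nM to 150000 nM in this assay here.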

Compound 3, half-maximal inhibitory concentration: 161000 nM
Compound 3: the middle estimate sits 2.3-fold (0.36 log units) below what was measured, and the stated range ends below it.
By their numbers in this assay, from the lowest: compounds 1, 2 and 3 (each within the scatter of the next, the first and the last beyond it).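

In this assay, among the compounds shown here, the change from 4-methylphenyl to 4-chlorophenyl gives a 1.8-fold higher number from compound 2 to compound 3 (0.26 log units; within the scatter) and so supplies the first measured pair for this swap. At this place on the aromatic ring, para to a large group, chloro and methyl cannot be told apart on this read-out. Nothing measured here offers an explanation for the step.

As far as these compounds go, whether an amine, a carboxylic acid or a methoxy group at the same place would give a step beyond the scatter remains open.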